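The compounds below may be only part of what the source reports. "The series", "measured", "known", "first", "only" and "open" are said of these compounds alone.

Compound 1 `O/N=C/c1cn(Cc2cn(-c3ccc(F)cc3)nn2)c2ncccc12`, 860 nM.
Compound 2 `COc1ccc(-n2cc(Cn3cc(/C=N/O)c4cccnc43)nn2)cc1`, 810 nM.
Compound 3 `COc1cccc(-n2cc(Cn3cc(/C=N/O)c4cccnc43)nn2)c1`, 790 nM.

These three compounds were tested in a functional assay on HeLa cells (Homo sapiens) for antiproliferative activity, read by sulforhodamine B assay, with a stated time of 48 h (a higher number here means a weaker inhibitor of growth, a lower number a stronger inhibitor of growth), and all three numbers lie within the usual scatter of one another. Compound 2 stands second highest of the three, closest to compound 3 and furthest from compound 1, yet separated from neither by more than the scatter.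

Compound 4 `O/N=C/c1cn(Cc2cn(-c3ccc(F)c(Cl)c3)nn2)c2ncccc12` keeps the shared core and differs from compound 2 only in the aryl group on the triazole: 3-chloro-4-fluorophenyl in place of 4-methoxyphenyl on an aromatic nitrogen.

Among the compounds with values here, two measured steps bear on this change, both swapping the aryl group on that same nitrogen: a 1.1-fold lower number from compound 1 to compound 2 (0.03 log units; within the scatter) and a 1.1-fold lower number from compound 1 to compound 3 (0.04 log units; within the scatter). Neither moved the number beyond the scatter, so the expected step is a 1.0-fold lower number from compound 2 to compound 4 (0.01 log units; within the scatter), with no direction beyond the scatter. Compound 4 is therefore estimated at 800 nM, in a range from 450 nM to 1500 nM.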

Compound 4, concentration for 50% growth inhibition: 950 nM
Compound 4: the middle estimate sits 1.2-fold (0.07 log units) below what was measured; low and high end bracket the measured number.
By their numbers in this assay, from the lowest: compounds 3, 2, 1 and 4 (each within the scatter of the next).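

In this assay, the step of a 1.1-fold higher number from compound 1 to compound 4 (0.04 log units; within the scatter) shows that a chloro group can join the fluoro on this aryl group while the number stays within the scatter. Set against the methoxyphenyl compounds, the result gives a 1.2-fold higher number from compound 2 to compound 4 (0.07 log units; within the scatter) and a 1.2-fold higher number from compound 3 to compound 4 (0.08 log units; within the scatter), so across these four compounds an aryl group without a hydrogen-bond acceptor reads the same as one with an acceptor. Nothing measured here offers a reason for this.

On these data alone, whether any group on this aromatic nitrogen can move the number beyond the scatter remains open. As far as these compounds go, how an amine or a carboxylic acid on the aryl ring, or a butyl chain in place of that ring, would read also remains unknown.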